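Swapping hydroxy for dimethylamino on a weak inhibitor

This account rests on a few compounds, and the source may have more. Where it says the series, first, only, none or still open, it means among the compounds named here.

In a functional assay on SK-MEL-28 cells (Homo sapiens) for inhibition (a higher number here means a weaker inhibitor, a lower number a stronger inhibitor), compound 1 (`Oc1ccc(/C=C/c2ccc3ccccc3c2)cc1`) gives 4060 nM and so holds the higher of the two exact numbers available. Compound 2 (`COc1cc(/C=C\c2ccc3ccccc3c2)ccc1F`) gives 450 nM in the same test, a lower number by a gap beyond the usual scatter. For compound 3 (`Cc1ccc(/C=C\c2ccc3ccccc3c2)cc1`) the reading is > 5000 nM and this is a limit of the test, not a number.

Compound 4 (`CN(C)c1ccc(/C=C/c2ccc3ccccc3c2)cc1`) keeps the core of compound 1 but carries dimethylamino in place of hydroxy on an aromatic carbon, para to a large group (dimethylamino in place of hydroxy on an aromatic carbon). Among the compounds with values here, no measured pair shows this exchange alone. The expectation therefore starts from compound 1 at 4060 nM as its anchor and foresees no change beyond the scatter in this assay for this swap. The step of a 1.4-fold lower number from compound 1 to compound 4 (0.13 log units; within the scatter) is expected to stay small, with a slightly lower number as the likeliest direction. For compound 4 the estimated value is 3000 nM with a range from 700 nM to 8000 nM as the expected span.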

Compound 4, half-maximal inhibitory concentration: 3660 nM
Compound 4: the middle estimate sits 1.2-fold (0.09 log units) below what was measured; the measured number falls inside the stated range.
By their numbers in this assay, from the lowest: compound 2; then compounds 4 and 1 (each within the scatter of the next). At a limit, above all of these: compound 3.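

Within the data shown here, this is the first pair that differs in one place only, so the effect of this exchange can be read on its own. In this assay, dimethylamino in place of hydroxy on an aromatic carbon, para to a large group, gives a 1.1-fold lower number from compound 1 to compound 4 (0.05 log units; within the scatter), so the two readings cannot be told apart. The exchange takes the hydrogen-bond donor count from 1 to 0 and adds heavy atoms, yet compound 4 reads no differently from compound 1 in this test.

Going by these compounds, whether a primary amine or a carboxylic acid in the same place would read differently stays open, as does whether this exchange would behave alike on a different core. Any reading for a much weaker compound in this series would also meet a ceiling: the limit of > 5000 nM in this assay, at which 1 of the 4 values shown sits.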